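The source may hold more compounds than are shown below. What is called first, only, known or untested is meant among the compounds shown, and "the series" means these compounds.

Measured compounds:
Compound 1 `COc1ccc(OC)c(-c2cc(-c3ccccc3)nn2-c2ccc(S(=O)(=O)NC(C)=O)cc2)c1` — 36200 nM
Compound 2 `Oc1ccc(O)c(-c2cc(-c3ccccc3)nn2-c2ccccc2)c1` — 63900 nM
Compound 3 `NS(=O)(=O)c1ccc(-n2nc(-c3ccccc3)cc2-c2cc(O)ccc2O)cc1` — 92000 nM

These three compounds were tested in a functional assay on cells (Melanoma cell, Homo sapiens) for cytotoxicity, read by sulforhodamine B assay, with a stated time of 48 h; on this read-out higher numbers stand for weaker inhibition of growth and lower numbers for stronger inhibition of growth. Compound 3 gives the highest of the three numbers; its nearest neighbour is compound 2, and the step of a 1.4-fold higher number from compound 2 to compound 3 (0.16 log units; within the scatter) is small, while compound 1 sits furthest from it with a lower number that lies beyond the scatter.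

Compound 4 `CC(=O)NS(=O)(=O)c1ccc(-n2nc(-c3ccccc3)cc2-c2cc(O)ccc2O)cc1` has not yet been measured. It differs from compound 3 in one place: acetyl in place of hydrogen on a sulfonamide nitrogen. Among the measured compounds shown here, no measured pair differs by exactly this change, so no single step speaks to it directly. Compound 1 does carry the acetyl on its sulfonamide nitrogen, but it also carries two methoxy groups where compound 3 carries two hydroxy groups, so its lower number cannot be read as the effect of the acetyl alone. For the measured compounds named here, the one step that is known, the small 1.4-fold higher number from compound 2 to compound 3 (0.16 log units; within the scatter), shows that altering the group on this ring changed little.

Compound 4 is therefore expected to land near compound 3, with the step of a 1.2-fold lower number from compound 3 to compound 4 (0.09 log units; within the scatter) not beyond the scatter; the estimate for compound 4 is 75000 nM, in a range from 32000 nM to 170000 nM.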

Compound 4, concentration for total growth inhibition: 100000 nM
Compound 4: the middle estimate sits 1.3-fold (0.12 log units) below what was measured; measured number inside the range.
By their numbers in this assay, from the lowest: compounds 1, 2, 3 and 4 (each within the scatter of the next, the first and the last beyond it).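

In this assay, the acetyl on the sulfonamide nitrogen makes no readable difference (a 1.1-fold higher number from compound 3 to compound 4 (0.04 log units; within the scatter)), and the whole acetylsulfamoyl group in place of hydrogen on an aromatic carbon also stays small (a 1.6-fold higher number from compound 2 to compound 4 (0.19 log units; within the scatter)). The acetyl could not be separated from the other groups before, but with it now present on both compounds, 2,5-dihydroxyphenyl in place of 2,5-dimethoxyphenyl gives a step that can be read (a 2.8-fold higher number from compound 1 to compound 4 (0.44 log units; beyond the scatter)), so the lower number of compound 1 goes with the 2,5-dimethoxyphenyl group and not with the acetyl. Nothing measured here explains either result.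

The compounds shown leave open whether a longer chain such as butanoyl on the sulfonamide nitrogen would behave as the acetyl does. They also leave open what a carboxylic acid in place of the sulfamoyl group would do.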